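This account rests on a few compounds, and the source may have more. Where it says the series, first, only, none or still open, it means among the compounds named here.

Compound 1 `Cc1ccccc1-c1nsc(=O)o1`: 18.1%
Compound 2 `COc1ccc(OC)c(-c2nsc(=O)o2)c1`: 25.3%

Of the compounds shown here, two have so far been tested in an ADME assay on L02 cells (Homo sapiens) for inhibition, read by MTT assay, with a stated time of 48 h, tested at 100 uM; a lower number here means less inhibition, a higher number more inhibition at the concentration tested (going by the name of the read-out). Compound 1 stands lowest of the two; its nearest neighbour is compound 2, whose value lies higher by an amount within the scatter, so the two cannot be told apart. Compound 3 `O=c1oc(-c2ccccc2Cl)ns1` has not yet been measured. It differs from compound 1 by chloro in place of methyl on an aromatic carbon. Within the data shown here, no measured step of this kind is available, so only a small step in this assay is expected, in either direction and not beyond the scatter. The estimate for compound 3 is 22%, with a range from 8% to 40%, meaning an expected step of a number 3.9 percentage points higher from compound 1 to compound 3 (within the scatter).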

Compound 3, a percentage reported as inhibition, at one concentration (the size of the read-out at that concentration, not a potency): 20.6%
For compound 3 the middle estimate is 1.4 percentage points above the measured one; the measured number falls inside the stated range.
By their numbers in this assay, from the lowest: compounds 1, 3 and 2 (each within the scatter of the next).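

In this assay, among these compounds, chloro in place of methyl on an aromatic carbon gives a number 2.5 percentage points higher from compound 1 to compound 3 (within the scatter), so at this position the exchange of these two single-atom groups produces no step that can be told from the scatter. Among the compounds shown here, this is the only step between compounds differing in one place, so it offers a first reading of this position. Nothing at hand bears on the reason for this result.

The compounds shown leave open whether an amine or a carboxylic acid at this position would also stay within the scatter. They also leave open how a longer chain there would read in this assay.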